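Trading chloro for trifluoromethyl on an aromatic ring

The source may hold more compounds than are shown below. What is called first, only, known or untested is meant among the compounds shown, and "the series" means these compounds.

In a functional assay on K562 cells (Homo sapiens) for cytotoxicity, read by trypan blue exclusion, with a stated time of 96 h (on this read-out lower numbers stand for stronger inhibition and higher numbers for weaker inhibition), compound 1 `COc1cc(C(=O)/C=C\Nc2ccccc2O)cc(OC)c1OC` gives 500 nM, compound 2 `COc1ccccc1N/C=C\C(=O)c1cc(OC)c(OC)c(OC)c1` gives 2500 nM and compound 3 `COc1cc(C(=O)/C=C\Nc2ccc(Cl)cc2)cc(OC)c1OC` gives 250 nM. Compound 3 therefore sits at the low end of the set, level with compound 1 within the scatter and clearly apart from compound 2.

Compound 4 `COc1cc(C(=O)/C=C\Nc2ccc(C(F)(F)F)cc2)cc(OC)c1OC` keeps the shared core but has trifluoromethyl in place of chloro on an aromatic carbon.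

Within the data shown here, no measured step makes this exact swap. The closest ones replace the whole substituted phenyl on the amine nitrogen, giving a 2.0-fold lower number from compound 1 to compound 3 (0.30 log units; within the scatter) in one case and a 10-fold lower number from compound 2 to compound 3 (1.00 log units; beyond the scatter) in another. The change in compound 4 is smaller, touching one group on that phenyl, so no step beyond the scatter is expected in this assay. The estimated step is a 1.2-fold higher number from compound 3 to compound 4 (0.08 log units; within the scatter). The range stays wide, as a single methyl on an oxygen already gives a 5.0-fold higher number from compound 1 to compound 2 (0.70 log units; beyond the scatter). For compound 4 the expected value is 300 nM, with an estimated range from 100 nM to 900 nM.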

Compound 4, half-maximal inhibitory concentration: 500 nM
The estimate for compound 4 lay 1.7-fold (0.22 log units) below the measured number, within the range that was stated.
By their numbers in this assay, from the lowest: compounds 3, 1 and 4 (each within the scatter of the next); then compound 2.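

In this assay, trifluoromethyl in place of chloro on an aromatic carbon, para to a large group, gives a 2.0-fold higher number from compound 3 to compound 4 (0.30 log units; within the scatter), so this assay cannot tell compound 3 and compound 4 apart. The earlier steps shown here replaced the whole substituted phenyl on the amine nitrogen, whereas this pair differs in one group alone: 4 heavy atoms enter where 1 heavy atom leaves, with no step beyond the scatter. No measurement shown here explains why the read-out holds steady across this swap.

Still open, on these data alone, is whether this tolerance extends to groups of a different kind at the same place, such as an amine or a carboxylic acid. Also open, as far as these compounds go, is whether a longer chain there, such as a butyl group, would leave the number within the scatter.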